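A few compounds are considered here, and "the series" means these few. Any claim that something is new, unique, unknown or untested is made for them only; others in the source may bear on it.

Measured in a functional assay on A2780 cells (Homo sapiens) for cytotoxicity, read by sulforhodamine B assay, with a stated time of 72 h; on this read-out higher numbers stand for weaker inhibition and lower numbers for stronger inhibition:
Compound 1 `O=C(NCc1ccc(S(=O)(=O)C2CCC(F)(F)CC2)cc1)N1Cc2ccncc2C1`: 13 nM
Compound 2 `O=C(NCc1ccc(S(=O)(=O)C2CCOCC2)cc1)N1Cc2ccncc2C1`: 35 nM

Compound 2, at 35 nM, has the higher of the two numbers. Compound 3 `O=C(NCc1ccc(S(=O)(=O)C2CCCOC2)cc1)N1Cc2ccncc2C1` is its isomer: oxan-3-yl in place of oxan-4-yl on a sulfonyl sulfur. For the measured compounds named here, the only measured change at that sulfur, a 2.7-fold higher number from compound 1 to compound 2 (0.43 log units; beyond the scatter), was modest and swapped a different group. A smaller shift is therefore expected here, with no direction favoured by the data, and the estimated step is a 1.1-fold higher number from compound 2 to compound 3 (0.06 log units; within the scatter). For compound 3 the expected value is 40 nM, with an estimated range of 15 nM to 100 nM.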

Compound 3, half-maximal inhibitory concentration: 32 nM
The estimate for compound 3 lay 1.3-fold (0.10 log units) above the measured number; low and high end bracket the measured number.
By their numbers in this assay, from the lowest: compound 1; then compounds 3 and 2 (each within the scatter of the next).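

In this assay, oxan-3-yl in place of oxan-4-yl on a sulfonyl sulfur gives a 1.1-fold lower number from compound 2 to compound 3 (0.04 log units; within the scatter), so the two oxane attachments are not told apart at this position. Replacing 4,4-difluorocyclohexyl with oxan-3-yl gives a 2.5-fold higher number from compound 1 to compound 3 (0.39 log units; beyond the scatter), which shows that the gap from compound 1 is not confined to the oxan-4-yl group. Nothing available here accounts for these numbers. Still open, as far as these compounds go, is how an amine-bearing ring such as piperidin-4-yl, or an open chain such as ethyl, would fare on the same sulfur.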